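Replacing the dimethylcarbamoyl group of compound 2

The source may report more compounds than this note shows. Statements on the series, on what has been measured and on what is new or still open speak of the compounds shown alone.

In a functional assay on the whole organism for inhibition, with Rattus norvegicus as the target, read by paw edema, with stated times of 1 h and 3 h (a higher number here means that more compound is needed for the effect, a lower number that less compound is needed), compound 1 `CCOC(=O)CO/N=C(\C)c1ccc(Cl)cc1` gives 32 mg/kg, while compound 2 `C/C(=N\OCC(=O)N(C)C)c1ccc(Cl)cc1` gives 120 mg/kg, the higher of the two numbers. Within the data shown here, only one measured step bears on the next change: a 3.8-fold higher number from compound 1 to compound 2 (0.57 log units; beyond the scatter), a modest move made by putting dimethylamino in place of ethoxy on a carbonyl carbon.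

Compound 3 `COC(=O)OCCO/N=C(\C)c1ccc(Cl)cc1` alters the same end of the chain, with ((methoxycarbonyl)oxy)methyl in place of dimethylcarbamoyl on a saturated chain carbon bound to an oxygen. Like compound 1, it lacks the dimethylamino group, although its entering group is longer and is not the ester of compound 1. Among the measured compounds shown here, the step to compound 2 was a 3.8-fold higher number from compound 1 to compound 2 (0.57 log units; beyond the scatter), so removing that group is expected to reverse part of that rise, though a single step is thin evidence and the data contain no direct precedent for the new group. The expected change is a 2.4-fold lower number from compound 2 to compound 3 (0.38 log units; beyond the scatter), a move toward a lower number that may not clear the scatter. For compound 3 the estimated value is 50 mg/kg, with an expected range from 16 mg/kg to 150 mg/kg.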

Compound 3, dose for half-maximal effect: 33 mg/kg
Compound 3: the middle estimate sits 1.5-fold (0.18 log units) above what was measured; the range from low to high includes it.
By their numbers in this assay, from the lowest: compounds 1 and 3 (each within the scatter of the next); then compound 2.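

Moving from dimethylcarbamoyl to ((methoxycarbonyl)oxy)methyl on a saturated chain carbon bound to an oxygen gives, in this assay, a 3.6-fold lower number from compound 2 to compound 3 (0.56 log units; beyond the scatter) and so shows that the earlier rise can be undone in full by a group other than ethoxycarbonyl. Set against the ester of the first compound, the change is a 1.0-fold higher number from compound 1 to compound 3 (0.01 log units; within the scatter) and thus makes no readable difference, even though the entering group of compound 3 carries 3 hydrogen-bond acceptors and is not the same kind of group as ethoxycarbonyl. Among these three compounds, then, only compound 2 with its dimethylcarbamoyl group stands apart, and no measurement offered here accounts for that difference.

The compounds shown leave open whether the higher number belongs to the dimethylamino group in particular or to amides at this place in general, which an unsubstituted carboxamide or a methylamide could help separate. They also leave open how a carboxylic acid, or a longer chain ending in an ester, would read at the same place on the shared core.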